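The source may report more compounds than this note shows. Statements on the series, on what has been measured and on what is new or still open speak of the compounds shown alone.

Notes on the series. The parent, compound 1 `NC(=O)c1c(NC(=O)c2ccccc2Cl)sc2c1CCNC2`, in a functional assay on HL-60 cells (Homo sapiens) for antiproliferative activity, with a stated time of 24 h (on this read-out lower numbers stand for stronger inhibition and higher numbers for weaker inhibition), gives 18600 nM. Compound 2 `Cc1ccccc1CN1CCc2c(sc(NC(=O)c3ccccc3Cl)c2C(N)=O)C1` carries a 2-methylbenzyl on the amine nitrogen in the ring; in this assay compound 2 returns only the limit > 50000 nM, which is a bound of the assay and not a number. The step of an at least 2.6-fold higher number from compound 1 to compound 2 (0.42 log units; beyond the scatter) is therefore known only as a bound. Compound 3 `NC(=O)c1c(NC(=O)c2ccccc2Cl)sc2c1CCN(Cc1ccc(Cl)cc1)C2` carries a 4-chlorobenzyl at the same place, and in this assay compound 3 gives 22500 nM. The step of a 1.2-fold higher number from compound 1 to compound 3 (0.08 log units; within the scatter) is flat, whereas an at least 2.2-fold lower number from compound 2 to compound 3 (0.34 log units; beyond the scatter) is the one that moves. That step starts from compound 2, whose value is the limit (the limit of > 50000 nM in this assay, at which 1 of the 3 values shown sits).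

Compound 4 `NC(=O)c1c(NC(=O)c2ccccc2Cl)sc2c1CCN(Cc1ccc(Cl)cc1Cl)C2` is next: 2,4-dichlorophenyl in place of 2-methylphenyl on a saturated chain carbon bound to an amine nitrogen in a ring. Within the data shown here, the only measured step on this position is the aryl swap an at least 2.2-fold lower number from compound 2 to compound 3 (0.34 log units; beyond the scatter), which also starts from compound 2. The entering 2,4-dichlorophenyl shares the chlorine of the 4-chlorophenyl of compound 3, so a downward step out of the limit toward the number of compound 3 is expected, of about the size of that swap, giving the expected step of an at least 2.0-fold lower number from compound 2 to compound 4 (0.30 log units; that floor lies within the scatter). Compound 4 is estimated at 25000 nM, with a range from 10000 nM to 60000 nM.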

Compound 4, half-maximal inhibitory concentration: 8010 nM
Compound 4: middle estimate off by 3.1-fold (0.49 log units), on the high side; the whole stated range lies above it.
By their numbers in this assay, from the lowest: compound 4; then compounds 1 and 3 (each within the scatter of the next). At a limit, above all of these: compound 2.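

In this assay, chloro in place of hydrogen on an aromatic carbon gives a 2.8-fold lower number from compound 3 to compound 4 (0.45 log units; beyond the scatter), so a substituent on the amine nitrogen in the ring now does more than leave the parent unchanged: a 2.3-fold lower number from compound 1 to compound 4 (0.37 log units; beyond the scatter). The step of an at least 6.2-fold lower number from compound 2 to compound 4 (0.79 log units; beyond the scatter) is known only as a bound, compound 2 being a limit and not a number: the limit of > 50000 nM in this assay, at which 1 of the 4 values shown sits. Compound 4 is the strongest of the compounds shown, but the link between more chlorine and stronger inhibition rests on compound 3 and compound 4 alone.

Going by these compounds, whether the gain belongs to chlorine as such or would also appear with a 2,4-difluorobenzyl stays open. So does the outcome with a pyridylmethyl, or with a longer chain such as phenethyl, in place of the benzyl.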